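Thienyl to methoxyphenyl at the vinyl carbon: compound 4

The source may hold more compounds than are shown below. What is called first, only, known or untested is meant among the compounds shown, and "the series" means these compounds.

Measured in a functional assay on DU-145 cells (Homo sapiens) for inhibition, read by trypan blue exclusion, with a stated time of 96 h; a higher number here means a weaker inhibitor of growth, a lower number a stronger inhibitor of growth:
- compound 1 `Cc1ccc(S(=O)(=O)/C(=C/c2sccc2C)C(=O)c2ccc(Cl)cc2)cc1`: 10000 nM
- compound 2 `Cc1ccc(S(=O)(=O)/C(=C/c2sccc2C)C(=O)c2ccc(Br)cc2)cc1`: 25000 nM
- compound 3 `CN(C)c1ccc(/C=C(/Sc2ccc(Br)cc2)C(=O)c2ccc(Cl)cc2)cc1`: > 100000 nM (a limit of the assay)

Of the two values that are actual numbers, compound 2 has the higher at 25000 nM. Its nearest neighbour is compound 1 at 10000 nM. Compound 3 gives only a limit, > 100000 nM.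

Compound 4 `COc1ccc(/C=C(\C(=O)c2ccc(Br)cc2)S(=O)(=O)c2ccc(C)cc2)cc1` is the next to be read in this assay. It carries 4-methoxyphenyl in place of 3-methylthiophen-2-yl on a double-bonded chain carbon bound to a double-bonded chain carbon.

For the measured compounds named here, the only measured step is a 2.5-fold higher number from compound 1 to compound 2 (0.40 log units; beyond the scatter), for bromo in place of chloro on an aromatic carbon. That step lies elsewhere in the molecule, so it gives only a rough sense of scale and no direction. Compound 3 differs from compound 2 in more than one place, so it offers no clean comparison. Going by the values given here, no measured pair changes the group at this carbon, so no direction is favoured and the range has to stay wide.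

The expected outcome is a 1.3-fold lower number from compound 2 to compound 4 (0.10 log units; within the scatter). For compound 4 the estimated value is 20000 nM, with an expected range from 4000 nM to 80000 nM.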

Compound 4, concentration for 50% growth inhibition: 1000 nM
Compound 4: the middle estimate sits 20-fold (1.30 log units) above what was measured, and the stated range ends above it.
By their numbers in this assay, from the lowest: compound 4; then compound 1; then compound 2. At a limit, above all of these: compound 3.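

In this assay, the group on a double-bonded chain carbon bound to a double-bonded chain carbon emerges as a strong determinant of the read-out, with 4-methoxyphenyl in place of 3-methylthiophen-2-yl giving a 25-fold lower number from compound 2 to compound 4 (1.40 log units; beyond the scatter) in a series where a direction at this carbon had not been shown. This step is clearly larger than the only earlier one, the change of bromo in place of chloro on an aromatic carbon, which gave a 2.5-fold higher number from compound 1 to compound 2 (0.40 log units; beyond the scatter) and so showed a much smaller effect of substitution elsewhere on the molecule. The swap replaces a five-membered aromatic ring with 1 hetero atom by a six-membered aromatic ring of carbon only and also adds a methoxy group, but nothing measured here accounts for the size of the step.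

A single pair cannot separate the effect of the ring from that of the methoxy group, and an unsubstituted phenyl or a 4-hydroxyphenyl at this carbon would be needed to make that separation. On these data alone, it also remains open whether the bromo and chloro step keeps its direction and size when 4-methoxyphenyl is present, which would take the chloro counterpart of compound 4.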